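The source may report more compounds than this note shows. Statements on the series, on what has been measured and on what is new or still open speak of the compounds shown alone.

Compound 1 `Nc1nc(N)c2c(-c3cc4ccccc4o3)cn([C@@H]3O[C@H](CO)[C@@H](O)[C@H]3O)c2n1`: > 20000 nM; compound 2 `C#Cc1cn([C@@H]2O[C@H](CO)[C@@H](O)[C@H]2O)c2ncnc(N(C)C)c12`: 90 nM; compound 3 `Cc1nc(N)c2c(-c3cc4ccccc4o3)cn([C@@H]3O[C@H](CO)[C@@H](O)[C@H]3O)c2n1`: > 20000 nM.

In a functional assay on CCRF-CEM cells (Homo sapiens), read by MTT assay, with a stated time of 72 h (on this read-out lower numbers stand for stronger inhibition and higher numbers for weaker inhibition), compound 3 gives only a limit, > 20000 nM. Compound 1 likewise gives only a limit, > 20000 nM, so the step that the two limits leave unreadable from compound 1 to compound 3 cannot be read, both sitting at the limit of > 20000 nM in this assay, at which 2 of the 3 values shown sit. Among the measured compounds shown here, compound 2 shows a number, 90 nM, but no single step links it to compound 3. Compound 4 `Cc1nc(N)c2c(I)cn([C@@H]3O[C@H](CO)[C@@H](O)[C@H]3O)c2n1` differs from compound 3 by iodo in place of 1-benzofuran-2-yl on an aromatic carbon. For the measured compounds named here, no measured step bears on this change, and the one step that might have set a scale is unreadable. Compound 4 is therefore expected to improve by an at least 6.6-fold lower number from compound 3 to compound 4 (0.82 log units; beyond the scatter) into a readable region, with wide uncertainty. Compound 4 is estimated at 3000 nM, between 200 nM and 20000 nM.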

Compound 4, half-maximal inhibitory concentration: 9030 nM
Estimate against measurement, compound 4: 3.0-fold (0.48 log units) below; low and high end bracket the measured number.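

In this assay, replacing 1-benzofuran-2-yl with iodo at this position gives the first readable change there: an at least 2.2-fold lower number from compound 3 to compound 4 (0.34 log units; beyond the scatter). The core of compound 3 can therefore give a measured number once the 1-benzofuran-2-yl group has left. The size of this step remains a minimum because compound 3 stands at a limit: the limit of > 20000 nM in this assay, at which 2 of the 4 values shown sit.

From the compounds shown here alone, it remains open whether bromo, phenyl or an amine at this position would behave more like iodo or like 1-benzofuran-2-yl. Going by these compounds, it also remains open whether amino in place of methyl would alter the number with iodo present.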